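Two weak brain-tumour cell growth inhibitors and a brominated analogue

A few compounds are considered here, and "the series" means these few. Any claim that something is new, unique, unknown or untested is made for them only; others in the source may bear on it.

Measured so far:
compound 1 `Cc1onc(-c2c(F)cccc2Cl)c1C(=O)Nc1c(-c2ccccc2)[nH]c2ccccc12`: 24000 nM
compound 2 `CCN(CC)C(=S)Sc1c(-c2ccccc2)[nH]c2ccc(Br)cc12`: 36000 nM

Both compounds were tested in a functional assay on U-373MG ATCC cells (Homo sapiens) for inhibition, read by MTT assay, with a stated time of 72 h; on this read-out higher numbers stand for weaker inhibition of growth and lower numbers for stronger inhibition of growth. Compound 1 gives 24000 nM, and compound 2 gives 36000 nM. Compound 2 has the highest number of the two, but its nearest neighbour is compound 1 and that gap lies within the scatter, so the two cannot be told apart on this read-out.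

The next compound, compound 3 `CCN(CC)C(=S)Sc1c(-c2ccc(Br)cc2)[nH]c2ccc(Br)cc12`, differs from compound 2 in one place: bromo in place of hydrogen on an aromatic carbon. The change sits on an aromatic carbon of a six-membered aromatic ring of carbon only, turning a phenyl into a 4-bromophenyl. Going by the values given here, no measured pair shows what such a change does here, so any expectation rests on compound 2 alone. The step from compound 2 to compound 3 in this assay is expected to be small, with no clear direction beyond the scatter, namely a 1.2-fold lower number from compound 2 to compound 3 (0.08 log units; within the scatter). Compound 3 is therefore estimated at 30000 nM, within a range from 12000 nM to 80000 nM.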

Compound 3, concentration for 50% growth inhibition: 9000 nM
Beside the measured number, compound 3's estimate is 3.3-fold (0.52 log units) above it, outside the stated range (below it).
By their numbers in this assay, from the lowest: compound 3; then compounds 1 and 2 (each within the scatter of the next).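

In this assay the phenyl group of compound 2 proves to be a position that responds to change: bromo in place of hydrogen gives a 4.0-fold lower number from compound 2 to compound 3 (0.60 log units; beyond the scatter) and that step lies beyond the scatter. A single added heavy atom on this aromatic ring, para to a large group, is thus enough to shift the number towards stronger inhibition of growth. This rests on one pair of compounds, so it describes this change on this core and sets no general trend.

As far as these compounds go, whether a smaller chloro, a methoxy or an amine at the same place would move the number in the same way stays open, as does whether the step depends on the bromo already present in compound 2. The data shown offer no measurement that bears on the reason for this step.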